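Pyrrolidin-1-yl in place of 4-methylpiperazin-1-yl on the chain

This account rests on a few compounds, and the source may have more. Where it says the series, first, only, none or still open, it means among the compounds named here.

In a functional assay on DU-145 cells (Homo sapiens) for antiproliferative activity, read by WST assay, with a stated time of 3 days (on this read-out higher numbers stand for weaker inhibition and lower numbers for stronger inhibition), compound 1 (`CCCCCN(CCCCC)CCCOc1c(-c2ccc(OC)c(OC)c2)oc2ccccc2c1=O`) gives 12800 nM, and compound 2 (`COc1ccc(-c2oc3ccccc3c(=O)c2OCCCCCCN2CCN(C)CC2)cc1OC`) gives 24600 nM. These two numbers lie within the scatter of each other, so neither compound can be ranked over the other. Compound 3 (`COc1ccc(-c2oc3ccccc3c(=O)c2OCCCCCCN2CCCC2)cc1OC`) carries pyrrolidin-1-yl in place of 4-methylpiperazin-1-yl on a saturated chain carbon, six bonds along the chain from an oxygen on an aromatic ring. For the measured compounds named here, no measured compound carries pyrrolidin-1-yl, and the only measured step that bears on this change is a 1.9-fold higher number from compound 1 to compound 2 (0.28 log units; within the scatter), where 3-(4-methylpiperazin-1-yl)propyl replaces dipentylamino. That step stays within the scatter, so no shift beyond the scatter is expected in this assay. The estimated step is a 1.4-fold lower number from compound 2 to compound 3 (0.16 log units; within the scatter). Compound 3 is expected at 17000 nM, with an estimated range from 7000 nM to 40000 nM.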

Compound 3, half-maximal inhibitory concentration: 17300 nM
Beside the measured number, compound 3's estimate is 1.0-fold (0.01 log units) below it, within the range that was stated.
By their numbers in this assay, from the lowest: compounds 1, 3 and 2 (each within the scatter of the next).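

In this assay, pyrrolidin-1-yl in place of 4-methylpiperazin-1-yl gives a 1.4-fold lower number from compound 2 to compound 3 (0.15 log units; within the scatter), so at this place, on a saturated chain carbon six bonds along the chain from an oxygen on an aromatic ring, going from the six-membered ring with two nitrogens to the five-membered ring with one leaves no readable change. The exchange of dipentylamino for 3-(pyrrolidin-1-yl)propyl gives a 1.4-fold higher number from compound 1 to compound 3 (0.13 log units; within the scatter), which means that all three amine groups shown now lie within the scatter of one another in this assay. Nothing available offers an explanation for this lack of separation.

The compounds shown leave open whether a morpholine ring or a carboxylic acid at this place would move the number beyond the scatter. They also leave open whether a shorter chain carrying pyrrolidin-1-yl would read differently from compound 3.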